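The source may report more compounds than this note shows. Statements on the series, on what has been measured and on what is new or still open speak of the compounds shown alone.

The series rests on a shared core, shown for compound 1 as `CC1=CC[C@H](C(C)C)c2cc(C)c(OC(=O)c3ccc([N+](=O)[O-])cc3)cc21`, in which the ester carries a substituted phenyl group. In a functional assay on K562 cells (Homo sapiens) for antiproliferative activity, read by sulforhodamine B assay, with a stated time of 48 h, tested at 50 uM (on this read-out lower numbers stand for less inhibition and higher numbers for more inhibition at the one concentration tested (going by the name of the read-out)), compound 1 gives 89%. Compound 2, `CC1=CC[C@H](C(C)C)c2cc(C)c(OC(=O)c3cccc(Cl)c3)cc21`, carries a 3-chlorophenyl ester, and in this assay compound 2 is reported as "not active" (no number reported), so no single number marks where it stands; it can only be said to sit far from compound 1. Compound 3, `CC1=CC[C@H](C(C)C)c2cc(C)c(OC(=O)c3cccc(C)c3)cc21`, differs from compound 2 by methyl in place of chloro on an aromatic carbon. Within the data shown here, no measured step relates this kind of change to the read-out, so the size and direction of the step in this assay cannot be drawn from the data, and a change beyond the scatter is not expected in either direction. Compound 3 is therefore estimated to give 15% in this assay, within a range of 0% to 50%.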

Compound 3, a percentage reported as inhibition, at one concentration (the size of the read-out at that concentration, not a potency): "not active" (no number reported)
The entry for compound 3 holds no number; there is nothing to compare the estimate with.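

In this assay compound 2 gives "not active" (no number reported) and compound 3 gives "not active" (no number reported), so no step can be read between them. No evidence bears on this result. The compounds shown leave open whether going from 3-chlorophenyl to 3-methylphenyl changes the inhibition at all.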